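Adding a Methoxy to Compound 3

This account rests on a few compounds, and the source may have more. Where it says the series, first, only, none or still open, it means among the compounds named here.

Compound 1 `COc1c(O)cc2occ(-c3csc4ccccc34)c(=O)c2c1O`: > 10000 nM (a limit)
Compound 2 `COc1cc2occ(-c3csc4ccccc34)c(=O)c2c(OC)c1OC`: 820 nM
Compound 3 `COc1cc2occ(-c3csc4ccccc34)c(=O)c2cc1OC`: > 10000 nM (a limit)

In a functional assay on MDA-MB-231 cells (Homo sapiens) for antiproliferative activity, read by sulforhodamine B assay, with a stated time of 72 h (on this read-out higher numbers stand for weaker inhibition and lower numbers for stronger inhibition), compound 3 stands at the limit of > 10000 nM in this assay, at which 2 of the 3 values shown sit, and this is a limit rather than a number. Compound 4 `COc1cc2c(=O)c(-c3csc4ccccc34)coc2c(OC)c1OC` differs from compound 3 by methoxy in place of hydrogen on an aromatic carbon. Within the data shown here, one measured step bears on this change: an at least 12-fold higher number from compound 2 to compound 3 (1.08 log units; beyond the scatter). That step is large and beyond the scatter, and it is the removal of a methoxy group. Read in reverse, it shows a methoxy in place of hydrogen going with stronger inhibition. However, compound 2 carries its extra methoxy on a different carbon from compound 4, so the earlier gain may not carry over in full. A smaller move towards stronger inhibition is therefore expected, and the result could still be reported only as a limit. The expected change is an at least 3.3-fold lower number from compound 3 to compound 4 (0.52 log units; beyond the scatter). Compound 4 is estimated at 3000 nM, with an expected range from 600 nM to 15000 nM.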

Compound 4, half-maximal inhibitory concentration: > 10000 nM
Compound 4 was reported as a limit; the forecaster's own chance of this, stated with the estimate: 40%; middle value at least 3.3-fold (0.52 log units) away from the limit.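

Compound 3 and compound 4 are both reported only as limits rather than numbers, so the step between them cannot be read: the limit of > 10000 nM in this assay, at which 3 of the 4 values shown sit.

The compounds shown leave open whether methoxy in place of hydrogen on this aromatic carbon changes inhibition at all, and by how much.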